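A few compounds are considered here, and "the series" means these few. Any claim that something is new, unique, unknown or untested is made for them only; others in the source may bear on it.

Measured so far in a functional assay on MCF7 cells (Homo sapiens) for antiproliferative activity, read by MTT assay, with a stated time of 72 h; on this read-out higher numbers stand for weaker inhibition and lower numbers for stronger inhibition:
- compound 1 `CCCSc1nc(N/N=C(\C)c2ccccc2O)c2nnn(Cc3ccco3)c2n1` gives 29000 nM
- compound 2 `CCCSc1nc(N/N=C/c2ccc(N(C)C)cc2)c2nnn(Cc3ccccc3)c2n1` gives 12200 nM
- compound 3 `CCCSc1nc(N/N=C(\C)c2ccccc2O)c2nnn(Cc3cccc(Cl)c3)c2n1` gives 39900 nM

Compound 2 gives the lowest of these three numbers in this assay; its gap to compound 1 and its gap to compound 3 are both beyond the scatter. Compound 4 `CCCSc1nc(N/N=C/c2ccccc2)c2nnn(Cc3ccccc3)c2n1` is not yet measured. It differs from compound 2 by hydrogen in place of dimethylamino on an aromatic carbon. Within the data shown here, no measured step matches this change. Among the measured compounds shown here, the only step recorded, a 1.4-fold higher number from compound 1 to compound 3 (0.14 log units; within the scatter), alters a different part of the molecule and stays within the scatter, so it gives no guidance here. For the measured compounds named here, compound 1 and compound 3 each differ from compound 2 in two places, so their values show only that the shared core tolerates several substituents with weak inhibition. With the dimethylamino group gone, compound 4 is expected to show a 1.8-fold higher number from compound 2 to compound 4 (0.26 log units; within the scatter), a modest loss. The estimate for compound 4 is 22000 nM, ranging from 8000 nM to 60000 nM.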

Compound 4, half-maximal inhibitory concentration: > 64000 nM
Compound 4 gave a limit, no number; the forecaster's own chance of this, stated with the estimate: 15%; middle value at least 2.9-fold (0.46 log units) from the limit.
By their numbers in this assay, from the lowest: compound 2; then compounds 1 and 3 (each within the scatter of the next). At a limit, above all of these: compound 4.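

In this assay, among these compounds, hydrogen in place of dimethylamino on the aromatic carbon gives an at least 5.2-fold higher number from compound 2 to compound 4 (0.71 log units; beyond the scatter) and so shows, as the earlier compounds could not, that this position matters. Going from 4-(dimethylamino)phenyl to phenyl costs compound 2 much of its modest inhibition, a loss well beyond the scatter. On these data alone, compound 4 gives a limit of the assay and not a number, so the true size of the loss stays unknown: the limit of > 64000 nM in this assay, at which 1 of the 4 values shown sits.

As far as these compounds go, whether a smaller group here, such as methoxy or a plain amine, would keep the inhibition remains open. So does whether the same change would matter with the furan-2-yl or 3-chlorophenyl groups of compound 1 and compound 3.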